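A Dimethylamino Swap on the Aryl Ketone

A few compounds are considered here, and "the series" means these few. Any claim that something is new, unique, unknown or untested is made for them only; others in the source may bear on it.

In a functional assay on WI-38 VA13 cells (Homo sapiens) for cytotoxicity (on this read-out lower numbers stand for an effect already at smaller amounts and higher numbers for an effect only at larger amounts of compound), compound 1 `Cc1c(C(=O)Cc2ccccc2)oc2cc(-c3ccccc3)cc(O)c12` gives only a limit, > 4 ug/mL. For the measured compounds named here, compound 2 `Cc1c(C(=O)c2ccc(F)c(F)c2)oc2cc(-c3ccccc3)cc(O)c12` gives 0.4 ug/mL, the only actual number so far. Compound 3 `Cc1c(C(=O)c2ccc(N(C)C)cc2)oc2cc(-c3ccccc3)cc(O)c12` differs from it by 4-(dimethylamino)phenyl in place of 3,4-difluorophenyl on a carbonyl carbon, with 4-(dimethylamino)phenyl in place of 3,4-difluorophenyl on a carbonyl carbon. Going by the values given here, one measured step bears on this place, an at least 10-fold lower number from compound 1 to compound 2 (1.00 log units; beyond the scatter), but it replaced benzyl, whereas compound 3 keeps a six-membered aromatic ring of carbon only. A much smaller change is therefore expected, namely a 1.5-fold higher number from compound 2 to compound 3 (0.18 log units; within the scatter), with no shift beyond the scatter. Compound 3 is estimated at 0.6 ug/mL, within an expected range of 0.2 ug/mL to 2 ug/mL.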

Compound 3, half-maximal effective concentration: > 4 ug/mL
Compound 3 gave a limit, no number; the forecaster's own chance of this, stated with the estimate: 10%; middle value at least 6.6-fold (0.82 log units) from the limit.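

In this assay, the step of an at least 10-fold higher number from compound 2 to compound 3 (1.00 log units; beyond the scatter) keeps a six-membered aromatic ring of carbon only on the carbonyl carbon and changes only what that ring carries. An aromatic ring at this place is therefore not enough on its own, and among the compounds shown only compound 2, with 3,4-difluorophenyl, gives an actual number. The step from compound 1 to compound 3 cannot be read, because both values are limits: the limit of > 4 ug/mL in this assay, at which 2 of the 3 values shown sit.

From the compounds shown here alone, it remains open whether the shift follows the loss of the two fluorine atoms or the arrival of the dimethylamino group. An unsubstituted phenyl or a methoxyphenyl on the carbonyl carbon would bear on that question.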